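Taking the trifluoromethyl group off compound 1

The source may report more compounds than this note shows. Statements on the series, on what has been measured and on what is new or still open speak of the compounds shown alone.

In a functional assay on PC-3 cells (Homo sapiens) for cytotoxicity, read by MTT assay, with a stated time of 72 h (on this read-out higher numbers stand for weaker inhibition and lower numbers for stronger inhibition), compound 1 `CNC(=O)c1cc(Oc2ccc(NC(=O)c3cc(-c4ccc(C(F)(F)F)cc4)ncn3)cc2F)ccn1` gives > 100000 nM, which is a limit of the assay and not a number. Compound 3 `CNC(=O)c1cc(Oc2ccc(NC(=O)c3cc(-c4ccccc4)ncn3)cc2F)ccn1` has not been measured yet. It differs from compound 1 in one place, with hydrogen in place of trifluoromethyl on an aromatic carbon, para to a large group, so that 4-(trifluoromethyl)phenyl becomes phenyl (hydrogen in place of trifluoromethyl on an aromatic carbon). For the measured compounds named here, no measured pair shows what this change does on its own. Going by the values given here, the only number to lean on comes from compound 2 `CNC(=O)c1cc(Oc2ccc(NC(=O)c3nccc(-c4ccc(OC)cc4)n3)cc2F)ccn1`, which reads 24300 nM in this assay, so a value inside the measurable range seems possible. The expected change is modest and towards stronger inhibition, an estimated step of an at least 2.0-fold lower number from compound 1 to compound 3 (0.30 log units; that floor lies within the scatter). Another result at the limit would not be a surprise. The estimate for compound 3 is 50000 nM, with an expected range from 15000 nM to 100000 nM.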

Compound 3, half-maximal inhibitory concentration: 44300 nM
Beside the measured number, compound 3's estimate is 1.1-fold (0.05 log units) above it, within the range that was stated.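

In this assay, putting hydrogen in place of trifluoromethyl on the aromatic carbon gives an at least 2.2-fold lower number from compound 1 to compound 3 (0.35 log units; beyond the scatter). For the compounds shown here, this is the first single change that can be read, and it shows that going from 4-(trifluoromethyl)phenyl to phenyl moves the read-out towards stronger inhibition, by more than the usual scatter. The step is only a floor, because compound 1 stands at a limit of the assay and not at a number: the limit of > 100000 nM in this assay, at which 1 of the 3 values shown sits.

On these data alone, whether an amine or a carboxylic acid on the same aromatic carbon would lower the number further stays open. The compounds shown also leave open whether the same change would have a similar effect on a different core, such as that of compound 2.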